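This account rests on a few compounds, and the source may have more. Where it says the series, first, only, none or still open, it means among the compounds named here.

Measured so far in an ADME assay on a cell-free system (plasma, Homo sapiens) for metabolic stability, with Plasma (Rattus norvegicus) as the target, read by HPLC, at pH 7.4; a lower number here means that the compound disappears faster, a higher number that the compound lasts longer: compound 1 `CC(=O)Oc1ccccc1C(=O)O[C@H]1CO[C@H]2[C@@H]1OC[C@H]2O` gives 0.055 h; compound 2 `CC(=O)Oc1ccccc1C(=O)O[C@H]1CO[C@H]2[C@@H]1OC[C@H]2OC(=O)c1ccccc1` gives 0.055 h; compound 3 `CC(=O)Oc1ccccc1C(=O)O[C@H]1CO[C@H]2[C@@H]1OC[C@H]2OC(=O)c1ccccc1OC(=O)c1ccccc1` gives 0.385 h.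

Compound 2 stands level with compound 1, the two lowest numbers of the three, and the shortest-lived. The step of no change at the digits printed from compound 1 to compound 2 (within the scatter) shows that adding a benzoyl ester on the core did not alter the half-life. The step of a 7.0-fold higher number from compound 2 to compound 3 (0.85 log units; beyond the scatter) shows that a benzoyloxy group on the aromatic carbon of that benzoyl ring lengthened it modestly.

Compound 4 `CC(=O)Oc1ccccc1C(=O)O[C@H]1CO[C@H]2[C@@H]1OC[C@H]2OC(=O)c1ccc(-c2ccccc2)cc1` carries a different addition on that same ring: phenyl in place of hydrogen on an aromatic carbon. Among the compounds with values here, only the step from compound 2 to compound 3 bears on it, and phenyl is not benzoyloxy, so a smaller rise is expected in this assay. The estimate for compound 4 is 0.15 h, range 0.05 h to 0.5 h, a step of a 2.7-fold higher number from compound 2 to compound 4 (0.44 log units; beyond the scatter).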

Compound 4, half-life: > 0.333 h
Compound 4 gave a limit, no number (the forecaster's own chance of this, stated with the estimate: 5%); middle value at least 2.2-fold (0.34 log units) from the limit.
By their numbers in this assay, from the lowest: compounds 1 and 2 (each within the scatter of the next); then compound 3.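

Compound 4 reads as a limit of the assay, not a number: the limit of > 0.333 h in this assay, at which 1 of the 4 values shown sits.

Even so, this assay shows an at least 6.0-fold higher number from compound 2 to compound 4 (0.78 log units; beyond the scatter), so the rise is beyond the scatter. Until now only the benzoyloxy group of compound 3 had lengthened the half-life; compound 4 shows that a phenyl ring of carbon only, para to a large group, also does so on this benzoyl ring.

From the compounds shown here alone, how far compound 4 lies past its limit remains open. So does whether an amine or a carboxylic acid on that same carbon would lengthen the half-life too.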